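The source may report more compounds than this note shows. Statements on the series, on what has been measured and on what is new or still open speak of the compounds shown alone.

Measured compounds in an assay on HEK293 cells for displacement of a labelled ligand from NPC1-like intracellular cholesterol transporter 1 (Homo sapiens); on this read-out lower numbers stand for stronger inhibition and higher numbers for weaker inhibition:

Compound 1 `CC(C)(C)c1ccc(C(=O)N2CCC3(CC2)C(=O)N(CC(=O)NCCC(=O)O)CN3c2ccccc2)cc1` gives 11400 nM.
Compound 2 `CC(C)(C)OC(=O)NCC1CCCN(C(=O)CN2CN(c3ccccc3)C3(CCN(C(=O)c4ccc(C5CCCCC5)cc4)CC3)C2=O)C1` gives 3800 nM.
Compound 3 `CC(C)(C)OC(=O)NCC1CCCN(C(=O)CN2CN(c3ccccc3)C3(CCN(C(=O)c4ccc(C(C)(C)C)cc4)CC3)C2=O)C1` gives 9500 nM.

Compound 2 stands lowest of the three numbers. Within the data shown here, its nearest neighbour is compound 3, and the only single-point step among the measured compounds is a 2.5-fold higher number from compound 2 to compound 3 (0.40 log units; beyond the scatter), tert-butyl in place of cyclohexyl on an aromatic carbon. Among the measured compounds shown here, compound 1 differs from compound 2 at more than one place, so its value shows only that the two numbers differ; no step is counted for that pair.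

Compound 4 `NC(=O)C1CCCN(C(=O)CN2CN(c3ccccc3)C3(CCN(C(=O)c4ccc(C5CCCCC5)cc4)CC3)C2=O)C1` keeps the shared core of compound 2, with the cyclohexyl retained, and changes one place: carbamoyl in place of ((tert-butoxycarbonyl)amino)methyl on a saturated ring carbon. For the measured compounds named here, no measured step touches that saturated ring carbon; the one measured step concerns a group on the aromatic ring and was modest. The measured data therefore do not fix the direction of this change, and a step of modest size in this assay is expected, with a slight lean toward a higher number. Compound 4 is expected to give 6000 nM, within 2000 nM to 18000 nM, which is an expected step of a 1.6-fold higher number from compound 2 to compound 4 (0.20 log units; within the scatter).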

Compound 4, half-maximal inhibitory concentration: 3100 nM
The estimate for compound 4 lay 1.9-fold (0.29 log units) above the measured number; the measured number falls inside the stated range.
By their numbers in this assay, from the lowest: compounds 4 and 2 (each within the scatter of the next); then compounds 3 and 1 (each within the scatter of the next).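

In this assay the saturated ring carbon two ring bonds from the ring nitrogen now has a measured step, a 1.2-fold lower number from compound 2 to compound 4 (0.09 log units; within the scatter), with the cyclohexyl retained. Going from ((tert-butoxycarbonyl)amino)methyl, with 9 heavy atoms, to carbamoyl, with 3, therefore leaves the two numbers within the scatter of each other, so the full ((tert-butoxycarbonyl)amino)methyl group is not required at this place to keep a number of this size. No available evidence bears on this result.

Still open, as far as these compounds go, is whether an aminomethyl group, a carboxylic acid or a longer chain at this ring carbon would give a number beyond the scatter of compound 2 and compound 4. Also open, from the compounds shown here alone, is whether carbamoyl at this place would give the same result with tert-butyl in place of cyclohexyl on the aromatic carbon.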